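Swapping the aryl substituent in a naphthoquinone-derived sulfonyl amidine series

The source may report more compounds than this note shows. Statements on the series, on what has been measured and on what is new or still open speak of the compounds shown alone.

Measured so far:
- compound 1 `Cc1ccc(S(=O)(=O)/N=C(/CCNC2=CC(=O)c3ccccc3C2=O)Nc2ccc(Cl)cc2)cc1`, 32400 nM in a functional assay on DU-145 cells (Homo sapiens) for cytotoxicity, read by MTT assay, with a stated time of 48 h; a lower number here means a stronger inhibitor, a higher number a weaker inhibitor
- compound 2 `Cc1ccc(S(=O)(=O)/N=C(/CCNC2=CC(=O)c3ccccc3C2=O)Nc2ccc(F)cc2)cc1`, 12200 nM in this assay

Compound 1 gives the highest number of the two measured compounds in this assay, that is, it is the weaker of the pair. For the measured compounds named here, the only measured step is a 2.7-fold lower number from compound 1 to compound 2 (0.42 log units; beyond the scatter), which moves compound 2 to a somewhat lower number than compound 1.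

Compound 3 `Cc1ccc(S(=O)(=O)/N=C(/CCNC2=CC(=O)c3ccccc3C2=O)Nc2cccc(C)c2)cc1` has not yet been measured. It differs from compound 1 in one place: 3-methylphenyl in place of 4-chlorophenyl on an amine nitrogen. This change touches the same aromatic ring that is changed between compound 1 and compound 2, but it puts a methyl on the ring and removes the chlorine rather than exchanging one halogen for another, so the measured step from compound 1 to compound 2 bears on it only loosely. It shows that altering this ring can shift the number by a modest amount. Going by the values given here, with no closer precedent, the expectation for compound 3 is a step of a 1.5-fold lower number from compound 1 to compound 3 (0.17 log units; within the scatter), small and uncertain in direction. The estimate for compound 3 is therefore 22000 nM, with a range from 7000 nM to 65000 nM.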

Compound 3, half-maximal inhibitory concentration: 10200 nM
The estimate for compound 3 lay 2.2-fold (0.33 log units) above the measured number; the measured number falls inside the stated range.
By their numbers in this assay, from the lowest: compounds 3 and 2 (each within the scatter of the next); then compound 1.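

In this assay, putting 3-methylphenyl in place of 4-chlorophenyl on the amine nitrogen gives a 3.2-fold lower number from compound 1 to compound 3 (0.50 log units; beyond the scatter), so a change that removes the chlorine and brings in a methyl can also move the number beyond the scatter, not just an exchange of one halogen for another. The 3-methylphenyl and 4-fluorophenyl groups cannot be told apart here, with a 1.2-fold lower number from compound 2 to compound 3 (0.08 log units; within the scatter), which leaves compound 1, with its 4-chlorophenyl group, as the weakest of the three, since its steps to both others lie beyond the scatter. Why the chlorine-bearing compound stands apart from the other two remains unexplained, as nothing measured here bears on that question.

Compound 3 differs from compound 1 in both the substituent and its numbered place on the ring, so the contribution of each cannot be separated. Also open, as far as these compounds go, is how the number would respond at this nitrogen to a plain phenyl, a ring carrying a methoxy group or a ring carrying a carboxylic acid.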